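From an Ethoxyethyl Chain to a Nitrobenzyl Arm

The source may report more compounds than this note shows. Statements on the series, on what has been measured and on what is new or still open speak of the compounds shown alone.

In a functional assay on a cell-free system (plasma, Oryctolagus cuniculus) for inhibition, with stated times of 5 min, 1 min and 6 min (on this read-out higher numbers stand for weaker inhibition and lower numbers for stronger inhibition), the three measured compounds stand as follows:

compound 1 `CCOCCOn1c(-c2cccc(C#N)c2)nc(C)c1C(=O)OCC`: 6250 nM
compound 2 `CCOC(=O)c1c(C)nc(-c2cccc(C#N)c2)n1OCCCO`: 11400 nM
compound 3 `CCOC(=O)c1c(C)nc(-c2cccc(C#N)c2)n1OCc1ccc(F)cc1`: 5880 nM

Compound 1 holds the second highest number of the three; its nearest neighbour is compound 3, a 1.1-fold lower number from compound 1 to compound 3 (0.03 log units; within the scatter), and its furthest is compound 2, a 1.8-fold higher number from compound 1 to compound 2 (0.26 log units; within the scatter). Compound 4 `CCOC(=O)c1c(C)nc(-c2cccc(C#N)c2)n1OCc1ccc([N+](=O)[O-])cc1` differs from compound 1 in one place: 4-nitrophenyl in place of ethoxymethyl on a saturated chain carbon bound to an oxygen on an aromatic ring. For the measured compounds named here, the step that bears most on this change is the one from compound 1 to compound 3, a 1.1-fold lower number from compound 1 to compound 3 (0.03 log units; within the scatter), where 4-fluorophenyl also replaced ethoxymethyl at the same place; the step of a 1.9-fold lower number from compound 2 to compound 3 (0.29 log units; within the scatter) likewise stayed within the scatter. Compound 4 is therefore expected to show a 1.0-fold lower number from compound 1 to compound 4 (0.02 log units; within the scatter), with an estimated value of 6000 nM, ranging from 2500 nM to 15000 nM.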

Compound 4, half-maximal inhibitory concentration: 8750 nM
Estimate against measurement, compound 4: 1.5-fold (0.16 log units) below; the range from low to high includes it.
By their numbers in this assay, from the lowest: compounds 3, 1, 4 and 2 (each within the scatter of the next).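

With 4-nitrophenyl in place of ethoxymethyl on the saturated chain carbon (a 1.4-fold higher number from compound 1 to compound 4 (0.15 log units; within the scatter)) and nitro in place of fluoro on an aromatic carbon (a 1.5-fold higher number from compound 3 to compound 4 (0.17 log units; within the scatter)), this assay shows that a substituent change on the aromatic arm, not only a swap of the whole arm, stays within the scatter. Set against the 2-hydroxyethyl group, the same arm also stays within it (a 1.3-fold lower number from compound 2 to compound 4 (0.11 log units; within the scatter)), so these steps leave all four compounds unseparated. Nothing measured here offers a reason for these small steps. As far as these compounds go, whether an amine or a carboxylic acid on that aromatic ring, or a longer chain in place of 2-ethoxyethyl, would move the number beyond the scatter remains open.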